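Rearranging a pentyl chain into neopentyl

A few compounds are considered here, and "the series" means these few. Any claim that something is new, unique, unknown or untested is made for them only; others in the source may bear on it.

Measured in a functional assay on the whole organism with Rattus norvegicus as the target (on this read-out higher numbers stand for an effect only at larger amounts of compound and lower numbers for an effect already at smaller amounts), the three compounds read as follows:
compound 1 `CCCc1ccc2nc(N)sc2c1` gives 6 mg/kg
compound 2 `CC(C)(C)c1ccc2nc(N)sc2c1` gives 4 mg/kg
compound 3 `CCCCCc1ccc2nc(N)sc2c1` gives 7.5 mg/kg

Compound 3 stands within the scatter of both others, with a 1.3-fold higher number from compound 1 to compound 3 (0.10 log units; within the scatter) and a 1.9-fold higher number from compound 2 to compound 3 (0.27 log units; within the scatter) as its steps. Compound 4 `CC(C)(C)Cc1ccc2nc(N)sc2c1` has the same atoms joined differently, pentyl becoming neopentyl, and the difference reads tert-butyl in place of butyl on a saturated chain carbon bound to an aromatic carbon in full. The closest exchange of a straight chain for tert-butyl is a 1.5-fold lower number from compound 1 to compound 2 (0.18 log units; within the scatter) and it stays small, like the two steps of compound 3. In this assay the expected step is a 1.4-fold lower number from compound 3 to compound 4 (0.13 log units; within the scatter) and thus none beyond the scatter. Compound 4 is expected at 5.5 mg/kg with an estimated range of 2.5 mg/kg to 12 mg/kg.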

Compound 4, dose for half-maximal effect: > 10 mg/kg
Compound 4: no number, only a limit (the forecaster's own chance of this, stated with the estimate: 3%); middle value at least 1.8-fold (0.25 log units) from the limit.
By their numbers in this assay, from the lowest: compounds 2, 1 and 3 (each within the scatter of the next). At a limit, above all of these: compound 4.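

In this assay compound 4 gives no number, only a limit: the limit of > 10 mg/kg in this assay, at which 1 of the 4 values shown sits.
Among the compounds shown here, compounds 1, 2 and 3 all lie within the scatter of one another, whereas neopentyl in place of tert-butyl on an aromatic carbon gives an at least 2.5-fold higher number from compound 2 to compound 4 (0.39 log units; beyond the scatter), the first step beyond it. The floors of the other two steps, an at least 1.3-fold higher number from compound 3 to compound 4 (0.12 log units; that floor lies within the scatter) and an at least 1.6-fold higher number from compound 1 to compound 4 (0.22 log units; that floor lies within the scatter), lie within the scatter, so branching the pentyl chain is not shown to separate compound 4 from the straight chains.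

Where compound 4 truly lies past its limit stays open. So does whether isobutyl on an aromatic carbon would read with the straight chains or with compound 4.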